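A Fluoro for a Methyl on Compound 2

The source may hold more compounds than are shown below. What is called first, only, known or untested is meant among the compounds shown, and "the series" means these compounds.

Values measured in a functional assay on NCI-H1975 cells (Homo sapiens) for cytotoxicity, read by MTT assay, with a stated time of 72 h (a higher number here means a weaker inhibitor, a lower number a stronger inhibitor), so far:
Compound 1 `O=C(N/N=C/c1ccco1)N1CCc2ncnc(Nc3cccc(Br)c3)c2C1` gives > 200000 nM (a limit)
Compound 2 `Cc1ccc(/C=N/NC(=O)N2CCc3ncnc(Nc4cccc(C(F)(F)F)c4)c3C2)cc1` gives 21300 nM

The entry for compound 1, > 200000 nM, is a limit and not a number. Going by the values given here, compound 2, at 21300 nM, therefore holds the only numeric value, so there is no second number against which to place it. Compound 3 `O=C(N/N=C/c1ccc(F)cc1)N1CCc2ncnc(Nc3cccc(C(F)(F)F)c3)c2C1` has not yet been measured. It departs from compound 2 by one change, (fluoro in place of methyl on an aromatic carbon), which is fluoro in place of methyl on an aromatic carbon, turning 4-methylphenyl into 4-fluorophenyl. Among the compounds with values here, no measured step in this small set sizes such a change. In this assay only a small shift is expected, with no firm direction and perhaps none beyond the scatter. The expected change is a 1.1-fold lower number from compound 2 to compound 3 (0.05 log units; within the scatter) in size. For compound 3 the estimated value is 19000 nM, with an expected range from 6500 nM to 60000 nM.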

Compound 3, half-maximal inhibitory concentration: 55600 nM
The estimate for compound 3 lay 2.9-fold (0.47 log units) below the measured number, within the range that was stated.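

In this assay, the change from 4-methylphenyl to 4-fluorophenyl gives a 2.6-fold higher number from compound 2 to compound 3 (0.42 log units; beyond the scatter), so the methyl gives the lower number of the two and this aromatic carbon, para to a large group, is not indifferent to what it carries. Going by these compounds alone, this is the first step in the set that sizes a single change, since the two earlier compounds differ from each other in more than one place. Nothing shown here accounts for the direction of this step.

With only methyl and fluoro shown on this carbon, it remains open how an amine, a methoxy group, a carboxylic acid or a longer chain such as ethyl would move the number, and whether any would fall lower than compound 2. As far as these compounds go, it also remains open whether the same change would give a step of similar size with bromo in place of the trifluoromethyl group.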